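The compounds below may be only part of what the source reports. "The series", "measured", "known", "first", "only" and "open" are said of these compounds alone.

In a functional assay on PC-3 cells (Homo sapiens) for cytotoxicity, read by MTT assay, with a stated time of 96 h (on this read-out lower numbers stand for stronger inhibition and higher numbers for weaker inhibition), the series has so far yielded no number. Compound 1 (`CC[C@H](NC)C(=O)N[C@@H]1C(=O)N2[C@@H](CC[C@@H]1CCN)CC[C@H]2C(=O)NC(c1ccccc1)c1ccccc1`) gives > 100000 nM as a limit of the assay. Compound 2 (`CC[C@H](N)C(=O)N[C@@H]1C(=O)N2[C@@H](CC[C@@H]1CCNC(=O)c1ccccc1)CC[C@H]2C(=O)NC(c1ccccc1)c1ccccc1`) gives > 100000 nM as a limit too. Compound 3 (`CC[C@H](NC)C(=O)N[C@@H]1C(=O)N2[C@@H](CC[C@@H]1CCNC(=O)c1ccccc1)CC[C@H]2C(=O)NC(c1ccccc1)c1ccccc1`) gives > 100000 nM as a limit as well, so it stands with the other two: the limit of > 100000 nM in this assay, at which 3 of the 3 values shown sit, and nothing in the series separates them.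

Compound 4 (`CC[C@H](NC)C(=O)N[C@@H]1C(=O)N2[C@@H](CC[C@@H]1CCNC(=O)NCc1ccccc1)CC[C@H]2C(=O)NC(c1ccccc1)c1ccccc1`) carries benzylamino in place of phenyl on a carbonyl carbon, which turns benzoyl into benzylcarbamoyl: benzylamino in place of phenyl on a carbonyl carbon is the whole difference.

Two measured steps reach compound 3: a step that the two limits leave unreadable from compound 1 to compound 3 and a step that the two limits leave unreadable from compound 2 to compound 3 are the only ones, and neither offers a size to carry over. Neither benzoyl nor methyl on an amine nitrogen has moved a reading off the limit, so no direction can be argued and no step beyond the scatter is expected.

The expected change is a number no higher from compound 3 to compound 4 (the limit leaves the size open) and is only an estimate. For compound 4 the estimated value is 100000 nM with an expected range of 40000 nM to 200000 nM and a reading at the limit again is the likeliest outcome.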

Compound 4, half-maximal inhibitory concentration: 83500 nM
For compound 4 the middle estimate is 1.2-fold (0.08 log units) above the measured one; low and high end bracket the measured number.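

In this assay, going by these compounds alone, compound 4 gives 83500 nM, the only reading that is a number. Benzylamino in place of phenyl on a carbonyl carbon is thus the one change shown that brings a reading off the limit. As far as these compounds go, the two readable steps are an at least 1.1-fold lower number from compound 3 to compound 4 (0.07 log units; that floor lies within the scatter) and an at least 1.1-fold lower number from compound 1 to compound 4 (0.07 log units; that floor lies within the scatter); both give only a floor, and their full size stays open. The earlier steps cannot be read, and the other three values remain limits of the assay, not numbers: the limit of > 100000 nM in this assay, at which 3 of the 4 values shown sit.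

From the compounds shown here alone, whether this reading depends on the nitrogen or on the added carbon of benzylamino stays open, and anilino or phenethylamino on the same carbonyl carbon would separate the two. Also open, going by these compounds, is whether methyl on the amine nitrogen still makes no visible difference once benzylcarbamoyl is present.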